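The source may hold more compounds than are shown below. What is called first, only, known or untested is meant among the compounds shown, and "the series" means these compounds.

Three compounds of the series carry numbers in a functional assay on MDA-MB-231 cells (Homo sapiens) for cytotoxicity, read by MTT assay, with a stated time of 24 h; on this read-out lower numbers stand for stronger inhibition and higher numbers for weaker inhibition. Compound 1 `O=C1/C(=C/c2ccccc2F)CN(Cc2cn(Cc3ccccc3Cl)nn2)C/C1=C\c1ccccc1F` gives 16500 nM; compound 2 `Cc1ccc(/C=C2\CN(Cc3cn(Cc4ccccc4Cl)nn3)C/C(=C\c3ccc(C)cc3)C2=O)cc1` gives 29000 nM; compound 3 `Cc1ccc(/C=C2\CN(Cc3cn(Cc4ccccc4F)nn3)C/C(=C\c3ccc(C)cc3)C2=O)cc1` gives 10000 nM. Compound 1 stands second highest of the three, lying within the scatter of both compound 2 and compound 3. Within the data shown here, the only single-point step measured so far is a 2.9-fold lower number from compound 2 to compound 3 (0.46 log units; beyond the scatter), fluoro in place of chloro on an aromatic carbon. Compound 4 `O=C1/C(=C/c2ccccc2F)CN(Cc2cn(Cc3cccc(Cl)c3)nn2)C/C1=C\c1ccccc1F` differs from compound 1 by 3-chlorophenyl in place of 2-chlorophenyl on a saturated chain carbon bound to an aromatic nitrogen. Among the measured compounds shown here, no measured step moves a chlorine to another place on the ring, so the step from compound 2 to compound 3 does not bear on this change. In this assay the expected step is therefore none beyond the scatter, no change at the digits printed from compound 1 to compound 4 (within the scatter). Compound 4 is expected near 16500 nM, between 6000 nM and 45000 nM.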

Compound 4, half-maximal inhibitory concentration: 12000 nM
For compound 4 the middle estimate is 1.4-fold (0.14 log units) above the measured one; the measured number falls inside the stated range.
By their numbers in this assay, from the lowest: compounds 3, 4, 1 and 2 (each within the scatter of the next, the first and the last beyond it).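

In this assay, among these compounds, the step 3-chlorophenyl in place of 2-chlorophenyl gives a 1.4-fold lower number from compound 1 to compound 4 (0.14 log units; within the scatter) and is the first direct reading of where the chlorine sits on this ring. On the core of compound 1, this read-out does not separate the two chlorine placements. No measured evidence bears on this result.

Going by these compounds, the move is read on that one core only, so its outcome on the core of compound 2 remains open. Also open, on these data alone, is whether an amine or a carboxylic acid in place of the chlorine would give a number beyond the scatter.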